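Phenyl in Place of Pyrrolidinyl on a Small Core

This account rests on a few compounds, and the source may have more. Where it says the series, first, only, none or still open, it means among the compounds named here.

The study compares two measured compounds in an assay on isolated protein for inhibition of Leucine-rich repeat serine/threonine-protein kinase 2 variant G2019S (Homo sapiens), read by TR-FRET and LanthaScreen, with stated times of 50 min and 30 min, in the presence of a further agent that is not named here; on this read-out lower numbers stand for stronger inhibition and higher numbers for weaker inhibition. Compound 1 `Cc1c(Nc2nc(N)c3c(C#N)c(N4CCC[C@H]4C)n(C)c3n2)cnn1[C@@H]1CCOC1` gives 12 nM in this assay, while compound 2 `Cn1c(N2CCCC2)c(C#N)c2c(N)ncnc21` gives 1910 nM. Compound 2 therefore stands at the higher of the two numbers, and its gap to compound 1 lies beyond the usual scatter. Among the measured compounds shown here, no step between two compounds that differ in one place is available, so the effect of any single change is not known from these data.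

Compound 3 `Cn1c(-c2ccccc2)c(C#N)c2c(N)ncnc21` has not yet been measured. It differs from compound 2 in one place: phenyl in place of pyrrolidin-1-yl on an aromatic carbon. Because compound 2 already gives 1910 nM, the step is expected to be small, slightly toward weaker inhibition, and the step of a 1.6-fold higher number from compound 2 to compound 3 (0.20 log units; within the scatter) is expected to lie near the edge of the scatter. Compound 3 is estimated at 3000 nM, within a range from 800 nM to 12000 nM.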

Compound 3, half-maximal inhibitory concentration: 483 nM
Compound 3: the middle estimate sits 6.2-fold (0.79 log units) above what was measured; the measured number lies below the stated range.
By their numbers in this assay, from the lowest: compound 1; then compound 3; then compound 2.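

Phenyl in place of pyrrolidin-1-yl on this aromatic carbon gives a 4.0-fold lower number from compound 2 to compound 3 (0.60 log units; beyond the scatter) in this assay, which shows that inhibition on the shared core responds to the group held at this position. The step is modest but beyond the scatter and runs toward stronger inhibition, so the five-membered non-aromatic ring and its hydrogen-bond acceptor are not required here, and a six-membered aromatic ring of carbon only serves better on this small core. No measurement shown here explains the gain.

On these data alone, whether phenyl would bring a similar gain on the core of compound 1, which differs from compound 3 in more than one place, remains open. As far as these compounds go, it is also open how a pyridyl ring, or a phenyl ring bearing an amine or a carboxylic acid, would behave at this position.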